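The source may hold more compounds than are shown below. What is called first, only, known or untested is meant among the compounds shown, and "the series" means these compounds.

Measured in a physicochemical assay for solubility, in phosphate buffer, measured as thermodynamic solubility, at pH 2; a lower number here means a less soluble compound, a higher number a more soluble compound:
compound 1 `CCC(CC)N1CCN(c2nc3c(c(Nc4ccc(C(F)(F)F)cc4)n2)CCN(c2ncccc2C(F)(F)F)CC3)CC1`: 243 ug/mL
compound 2 `CC(C)(C)OC(=O)N1CCCC(Nc2nc3c(c(Nc4ccc(C(F)(F)F)cc4)n2)CCN(c2ncccc2C(F)(F)F)CC3)C1`: 1 ug/mL

Compound 1 stands highest of the two in this assay, and compound 2 lies far lower, with the gap beyond the scatter. Among the measured compounds shown here, no measured pair yet differs in one place only, so these two values give no direct size for the change considered next.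

Compound 3 `FC(F)(F)c1ccc(Nc2nc(N3CCN(C4CCC4)CC3)nc3c2CCN(c2ncccc2C(F)(F)F)CC3)cc1` keeps the core of compound 1 and differs at one place: cyclobutyl in place of pentan-3-yl on an amine nitrogen in a ring. Cyclobutyl replaces pentan-3-yl on an amine nitrogen in a ring, and neither group carries a net charge. No step beyond the scatter is expected in this assay, and neither direction is favoured. The expected size is given by a 1.1-fold higher number from compound 1 to compound 3 (0.03 log units; within the scatter), an estimate that stays small. The anchor for this expectation is compound 1 at 243 ug/mL, and the wide range reflects how little the two measured values show about this position. Compound 3 is estimated at 260 ug/mL, with an expected range of 90 ug/mL to 700 ug/mL.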

Compound 3, solubility: > 237 ug/mL
Compound 3 ended at the assay's limit; the forecaster's own chance of this, stated with the estimate: 3%; the middle value lies beyond the limit too.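

In this assay compound 3 gives > 237 ug/mL, which is a limit of the assay and not a number. Among the compounds shown here, no step from compound 1 to compound 3 can be read. The compounds shown leave open how large a difference, if any, cyclobutyl in place of pentan-3-yl on an amine nitrogen in a ring makes to this read-out.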